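The source may hold more compounds than are shown below. What is called first, only, known or untested is meant among the compounds shown, and "the series" means these compounds.

Measured so far in an assay on cells for inhibition of HSP60/HSP10 (Homo sapiens), with a stated time of 60 min; on this read-out lower numbers stand for stronger inhibition and higher numbers for weaker inhibition:
compound 1, `O=S(=O)(Nc1ccc(-c2nc3ccccc3o2)cc1)c1ccccc1Cl`, gives > 100000 nM, which is a limit of the assay and not a number.
compound 2, `O=[N+]([O-])c1cc(S(=O)(=O)Nc2ccc3oc(-c4ccccc4)nc3c2)ccc1Cl`, gives 17000 nM.

Compound 1 stands at the top of the range covered, where (the limit of > 100000 nM in this assay, at which 1 of the 2 values shown sits); nothing more than that limit is known for compound 1. Going by the values given here, compound 2 carries its sulfonamide on a different part of the shared core and bears a nitro group as well, so compound 1 and compound 2 differ in more than one place, and their two values show only that compound 2 reaches a measurable concentration in this assay while compound 1 does not. Among the compounds with values here, no step between two measured compounds that differ in one place is available, so the size of a single change has not been seen.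

Compound 3, `O=S(=O)(Nc1ccc(-c2nc3ccccc3o2)cc1)c1ccc(Cl)cc1`, differs from compound 1 by 4-chlorophenyl in place of 2-chlorophenyl on a sulfonyl sulfur. Within the data shown here, with compound 1 known only as a limit, no step in this assay can be sized from the measured pair, and nothing among the measured compounds points to a direction for this change. The step from compound 1 to compound 3 is expected to be an at least 1.2-fold lower number from compound 1 to compound 3 (0.09 log units; that floor lies within the scatter), that is, no movement beyond the usual scatter in either direction. For compound 3 the estimated value in this assay is 80000 nM, with a range from 15000 nM to 400000 nM, and a fair chance that the assay again reports only a limit.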

Compound 3, half-maximal inhibitory concentration: 61000 nM
The estimate for compound 3 lay 1.3-fold (0.12 log units) above the measured number, and the stated range covers the measured number.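

Going by these compounds alone, the change from 2-chlorophenyl to 4-chlorophenyl on a sulfonyl sulfur is the first single change with a readable step in this assay, and it gives an at least 1.6-fold lower number from compound 1 to compound 3 (0.21 log units; that floor lies within the scatter). With this change, compound 3 gives a measured number of 61000 nM, so a compound with the sulfonamide placement of compound 1 can now be read in this assay as a number. Compound 1 remains a limit of the assay and not a number, so the step is known only as a floor that does not clear the usual scatter, and its true size cannot be read, because compound 1 sits at the top of the range: the limit of > 100000 nM in this assay, at which 1 of the 3 values shown sits.

On these data alone, whether a methoxy group or an amine in place of the chlorine on this phenyl ring would move the number in this assay remains open. Also open, as far as these compounds go, is how the sulfonamide placement and the nitro group each bear on compound 2, which gives 17000 nM, since neither is seen alone as a single change.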